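The source may report more compounds than this note shows. Statements on the series, on what has been measured and on what is new or still open speak of the compounds shown alone.

In an ADME assay for permeability, using PAMPA (on this read-out higher numbers stand for higher permeability and lower numbers for lower permeability), compound 1 (`O=C(Nc1ccccc1Cl)c1cc(Cl)ccc1O`) gives 118 10^-6 cm/s, the higher of the two numbers available, while compound 2 (`O=C(Nc1ccc(F)cc1Cl)c1cc(Cl)ccc1O`) gives 50.5 10^-6 cm/s. For compound 3 (`O=C(Nc1ccc(Cl)cc1Cl)c1cc(Cl)ccc1O`) the result is only a limit, < 22.4 10^-6 cm/s. Compound 4 (`O=C(Nc1c(Cl)cccc1Cl)c1cc(Cl)ccc1O`) differs from compound 1 by chloro in place of hydrogen on an aromatic carbon, ortho to a large group and meta to a chloro group. Going by the values given here, two measured steps bear on this change. The same exchange made at another place gave an at least 5.2-fold lower number from compound 1 to compound 3 (0.72 log units; beyond the scatter), and fluoro in place of hydrogen gave a 2.3-fold lower number from compound 1 to compound 2 (0.37 log units; beyond the scatter). Given those steps, a modest downward step is expected in this assay. Compound 4 is estimated at 45 10^-6 cm/s, with an expected range from 15 10^-6 cm/s to 110 10^-6 cm/s. The estimated change is a 2.6-fold lower number from compound 1 to compound 4 (0.42 log units; beyond the scatter).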

Compound 4, apparent permeability: 73 10^-6 cm/s
Compound 4: the middle estimate sits 1.6-fold (0.21 log units) below what was measured; measured number inside the range.
By their numbers in this assay, from the lowest: compounds 2, 4 and 1 (each within the scatter of the next, the first and the last beyond it). At a limit, below all of these: compound 3.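

In this assay, chloro in place of hydrogen, ortho to a large group and meta to a chloro group, gives a 1.6-fold lower number from compound 1 to compound 4 (0.21 log units; within the scatter). The earlier compounds showed this exchange only at another place, where it gave an at least 5.2-fold lower number from compound 1 to compound 3 (0.72 log units; beyond the scatter), so among these compounds the same exchange does not give the same step at both places. The value of compound 3 is a limit and not a number: the limit of < 22.4 10^-6 cm/s in this assay, at which 1 of the 4 values shown sits.

The compounds shown leave open whether a fluoro group, a methoxy group or an amine at this position would also give a step within the scatter.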